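Trifluoromethyl in Place of Fluoro on the Aromatic Ring

A few compounds are considered here, and "the series" means these few. Any claim that something is new, unique, unknown or untested is made for them only; others in the source may bear on it.

Measured in a functional assay on the whole organism (strain Swiss) with Mus musculus as the target, in the maximal electroshock model, with a stated time of 0.25 h, at a dose of 100 mg/kg by the intraperitoneal route; a higher number here means a stronger effect of the compound at the dose given, a lower number a weaker effect:
Compound 1 `CC(C(=O)N1CCN(c2ccccc2)CC1)N1C(=O)CCC1=O`: 50%
Compound 2 `CC(C(=O)N1CCN(c2ccc(Cl)cc2)CC1)N1C(=O)CCC1=O`: 50%
Compound 3 `CC(C(=O)N1CCN(c2ccccc2F)CC1)N1C(=O)CCC1=O`: 75%

Compound 3 stands highest of the three: the step of a number 25 percentage points higher from compound 1 to compound 3 (beyond the scatter) and the step of a number 25 percentage points higher from compound 2 to compound 3 (beyond the scatter) both lie beyond the scatter, while the step of no change at the digits printed from compound 1 to compound 2 (within the scatter) stays within it. Compound 4 `CC(C(=O)N1CCN(c2ccccc2C(F)(F)F)CC1)N1C(=O)CCC1=O` keeps the shared core of compound 3 and differs in one place: trifluoromethyl in place of fluoro on an aromatic carbon. Within the data shown here, no measured pair swaps fluoro for trifluoromethyl, so the nearest guides are the two steps from compound 1, where fluoro gave a modest rise and chloro gave none. A larger halogen-bearing group did not help in that comparison, so the expected step of a number 15 percentage points lower from compound 3 to compound 4 (beyond the scatter) is estimated to be small, leaning slightly downward, most likely within the scatter. Compound 4 is therefore expected to show about 60% in this assay, with a range from 30% to 90%.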

Compound 4, a percentage reported as activity, at one dose (the size of the read-out at that dose, not a potency): 100%
Estimate against measurement, compound 4: 40 percentage points below; the whole stated range lies below it.
By their numbers in this assay, from the lowest: compounds 1 and 2 (each within the scatter of the next); then compound 3; then compound 4.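

At this place, on an aromatic carbon ortho to a large group, fluoro can give way to the bigger trifluoromethyl and the effect in this assay still climbs, with a number 25 percentage points higher from compound 3 to compound 4 (beyond the scatter). Measured against hydrogen at the same carbon, the whole change is a number 50 percentage points higher from compound 1 to compound 4 (beyond the scatter), so this place now shows two rising steps in a row, hydrogen to fluoro and then fluoro to trifluoromethyl, a gain that the chloro of compound 2 did not give over compound 1. No measurement is at hand that accounts for this rise.

From the compounds shown here alone, compound 4 gives 100% at one dose only, so how far its effect would hold at lower doses stays open. Also open, going by these compounds, is whether the rise needs fluorine at all, which a plain methyl or a methoxy group at this same place would test, and whether trifluoromethyl would do the same elsewhere on the ring.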